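The compounds below may be only part of what the source reports. "The series", "measured", "known", "first", "only" and "open" are said of these compounds alone.

Measured compounds: compound 1 `NS(=O)(=O)c1cc(-c2nnc(CN3CCN(Cc4ccccc4)CC3)o2)c(Cl)cc1SCc1ccccc1` gives 0.08 h in an ADME assay on microsomes from liver (Homo sapiens) for metabolic stability, read by LC-MS, using NADPH, tested at 5 uM; on this read-out higher numbers stand for a longer-lived compound and lower numbers for a shorter-lived compound; compound 2 `Cc1ccc(C)c(N2CCN(Cc3nnc(-c4cc(S(N)(=O)=O)c(SCc5ccccc5)cc4Cl)o3)CC2)c1` gives 0.208 h; compound 3 `NS(=O)(=O)c1cc(-c2nnc(Cn3cc(-c4ccccc4)nn3)o2)c(Cl)cc1SCc1ccccc1` gives 0.21 h.

Compound 3 holds the highest of the three numbers, but its gap to compound 2 is within the scatter; only compound 1 lies beyond it. Compound 4 `NS(=O)(=O)c1cc(-c2nnc(/C=C/c3c(Cl)cccc3Cl)o2)c(Cl)cc1SCc1ccccc1` differs from compound 3 by 2-(2,6-dichlorophenyl)ethenyl in place of (4-phenyl-1H-1,2,3-triazol-1-yl)methyl on an aromatic carbon. Among the compounds with values here, the one measured step, a 2.6-fold higher number from compound 1 to compound 2 (0.41 log units; beyond the scatter), touches a different part of the molecule and was modest; no measured pair bears directly on the change at this carbon. Compound 4 is therefore expected to show no step beyond the scatter, a 1.1-fold lower number from compound 3 to compound 4 (0.02 log units; within the scatter). The estimate for compound 4 is 0.2 h, in the range 0.08 h to 0.5 h.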

Compound 4, half-life: 0.468 h
Compound 4: middle estimate off by 2.3-fold (0.37 log units), on the low side; low and high end bracket the measured number.
By their numbers in this assay, from the lowest: compound 1; then compounds 2 and 3 (each within the scatter of the next); then compound 4.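

In this assay, within the data shown here, replacing (4-phenyl-1H-1,2,3-triazol-1-yl)methyl with 2-(2,6-dichlorophenyl)ethenyl on the aromatic carbon gives a 2.2-fold higher number from compound 3 to compound 4 (0.35 log units; beyond the scatter) and is the first measured step at this position. The read-out therefore answers to a change here as well as to the change on the ring amine nitrogen, although this step is also modest. Nothing available explains the step.

The compounds shown do not separate the contribution of the 2,6-dichlorophenyl ring from that of the ethenyl link. From the compounds shown here alone, how an ethyl link, an amine or a carboxylic acid on this carbon would read remains open.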